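Swapping the aryl group on the enone chain of compound 3

This account rests on a few compounds, and the source may have more. Where it says the series, first, only, none or still open, it means among the compounds named here.

Three compounds share one core and are tested in a functional assay on HeLa cells (Homo sapiens) for inhibition, read by sulforhodamine B assay, with a stated time of 48 h; on this read-out higher numbers stand for weaker inhibition of growth and lower numbers for stronger inhibition of growth. Compound 1 `CC(=O)OC/C(=C\c1ccccc1[N+](=O)[O-])C(=O)c1ccccc1` gives 25000 nM. Compound 2 `O=C(OC/C(=C\C1CCCCC1)C(=O)c1ccccc1)c1ccccc1` gives 24000 nM. Compound 3 `O=C(OC/C(=C\c1ccc(Cl)cc1Cl)C(=O)c1ccccc1)c1ccccc1` gives 20000 nM, the lowest of the three, though every gap to the other two lies within the scatter. Among the compounds with values here, the one step measured along the chain, a 1.2-fold lower number from compound 2 to compound 3 (0.08 log units; within the scatter), shows nothing beyond the scatter. Compound 4 `O=C(OC/C(=C\c1ccccc1[N+](=O)[O-])C(=O)c1ccccc1)c1ccccc1` differs from compound 3 by 2-nitrophenyl in place of 2,4-dichlorophenyl on a double-bonded chain carbon bound to a double-bonded chain carbon. Compound 1 already carries this 2-nitrophenyl group and sits close to compound 3, so no step beyond the scatter is expected in this assay, estimated as a 1.1-fold higher number from compound 3 to compound 4 (0.04 log units; within the scatter). Compound 4 is therefore expected to give about 22000 nM, within 11000 nM to 44000 nM.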

Compound 4, concentration for 50% growth inhibition: 22000 nM
Beside the measured number, compound 4's estimate shows no gap at the digits printed; measured number inside the range.
By their numbers in this assay, from the lowest: compounds 3, 4, 2 and 1 (each within the scatter of the next).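

In this assay, the step to 2-nitrophenyl from 2,4-dichlorophenyl gives a 1.1-fold higher number from compound 3 to compound 4 (0.04 log units; within the scatter) and the step to it from cyclohexyl gives a 1.1-fold lower number from compound 2 to compound 4 (0.04 log units; within the scatter) so these three groups on a double-bonded chain carbon cannot be told apart. The carbonyl carbon can now be read too: phenyl in place of methyl gives a 1.1-fold lower number from compound 1 to compound 4 (0.06 log units; within the scatter) and this change also stays inside the scatter. No measured evidence here offers a reason for these results. From the compounds shown here alone, whether an amine or a carboxylic acid on the double-bonded chain carbon, or a longer chain on the carbonyl carbon, would move the number beyond the scatter remains open.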